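From a Propargyl Chain to a Propargyl Amide

A few compounds are considered here, and "the series" means these few. Any claim that something is new, unique, unknown or untested is made for them only; others in the source may bear on it.

Measured in a functional assay on A-375 cells (Homo sapiens) for cytotoxicity, read by MTT assay, with a stated time of 48 h; a lower number here means a stronger inhibitor, a higher number a weaker inhibitor:
compound 1 `C#CCOC(=O)Cn1cnc2c1c(=O)n(C)c(=O)n2C`: 33600 nM
compound 2 `C#CCn1cnc2c1c(=O)n(C)c(=O)n2C`: 153000 nM
compound 3 `CCn1c(=O)ccn(C2OC(Cn3cc(COC(=O)Cn4cnc5c4c(=O)n(C)c(=O)n5C)nn3)C(OC)C2OC)c1=O`: 62800 nM

Compound 2 gives the highest number of the three, with compound 3 nearest and compound 1 furthest. Compound 4 `C#CCNC(=O)Cn1cnc2c1c(=O)n(C)c(=O)n2C` differs from compound 2 in one place: propargylcarbamoyl in place of ethynyl on a saturated chain carbon bound to an aromatic nitrogen. Among the compounds with values here, only one measured step touches this position, a 4.6-fold higher number from compound 1 to compound 2 (0.66 log units; beyond the scatter), where removing the propargyloxycarbonyl group raised the number. Compound 4 restores a group of similar make-up, an amide instead of an ester, at the same carbon, so a step of roughly that size back down is expected, a 4.4-fold lower number from compound 2 to compound 4 (0.64 log units; beyond the scatter). Compound 4 is therefore estimated at 35000 nM, with a range from 12000 nM to 100000 nM.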

Compound 4, half-maximal inhibitory concentration: 28200 nM
Estimate against measurement, compound 4: 1.2-fold (0.09 log units) above, and the stated range covers the measured number.
By their numbers in this assay, from the lowest: compounds 4, 1 and 3 (each within the scatter of the next, the first and the last beyond it); then compound 2.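

The step of a 5.4-fold lower number from compound 2 to compound 4 (0.73 log units; beyond the scatter) shows that the fall in the number seen with the ester group also occurs with propargylcarbamoyl on the saturated chain carbon bound to an aromatic nitrogen. The swap of propargyloxy for propargylamino on the carbonyl carbon gives a 1.2-fold lower number from compound 1 to compound 4 (0.08 log units; within the scatter), so in this assay the amide and the ester cannot be told apart, even though the amide adds a hydrogen-bond donor. Nothing available explains these results. As far as these compounds go, what a carboxylic acid, or an amide with a saturated propyl chain in place of the propargyl group, would give at this carbon remains open.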